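Swapping a Nitro for an Acetyl on a Potent Antagonist

This account rests on a few compounds, and the source may have more. Where it says the series, first, only, none or still open, it means among the compounds named here.

Measured compounds:
compound 1, `CCc1nc(N)nc(N)c1-c1ccc(NCc2ccc(C(C)=O)cc2)cc1`, with 110 nM
compound 2, `Nc1nc(N)c(-c2ccc(NCc3ccc([N+](=O)[O-])cc3)cc2)c(COCc2ccccc2)n1`, with 5.8 nM

Both were tested in a functional assay on CHOK cells for antagonist activity at growth hormone secretagogue receptor type 1 (Homo sapiens), read by calcium flux; a lower number here means a stronger inhibitor, a higher number a weaker inhibitor. Compound 2 stands lowest of the two numbers; its nearest neighbour is compound 1, whose value is a great deal higher, and that gap lies well beyond the scatter of the measurement. Compound 1 and compound 2 differ in two places at once, so their values alone do not tell what either change contributes on its own.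

Compound 3, `CC(=O)c1ccc(CNc2ccc(-c3c(N)nc(N)nc3COCc3ccccc3)cc2)cc1`, is not yet measured. It keeps the core and the benzyloxymethyl side group of compound 2 and changes only the far end of the benzylamino arm: acetyl in place of nitro on an aromatic carbon. The group that enters is the same one that compound 1 carries at that position. Among the compounds with values here, with no single-change pair available, the expectation rests on the closeness of the two groups as counted above. The estimate for compound 3 in this assay is 12 nM, within 4 nM to 40 nM, meaning an expected step of a 2.1-fold higher number from compound 2 to compound 3 (0.32 log units; beyond the scatter) that may not exceed the scatter.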

Compound 3, half-maximal inhibitory concentration: 10 nM
Compound 3: middle estimate off by 1.2-fold (0.08 log units), on the high side; low and high end bracket the measured number.
By their numbers in this assay, from the lowest: compounds 2 and 3 (each within the scatter of the next); then compound 1.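

In this assay, acetyl in place of nitro on the aromatic carbon gives a 1.7-fold higher number from compound 2 to compound 3 (0.24 log units; within the scatter), so at this position the two groups cannot be told apart, although they differ in their atoms and in their count of hydrogen-bond acceptors. Within the data shown here, compound 3 also gives the first single-change reading of the side group: benzyloxy in place of methyl on the saturated chain carbon gives an 11-fold lower number from compound 1 to compound 3 (1.04 log units; beyond the scatter), which shows that, with acetyl held constant, this change alone accounts for a large step, unlike the swap at the far end of the arm. Nothing shown here explains the size of either step.

Nitro and acetyl each have three heavy atoms and one double bond outside aromatic rings, so it remains open whether a differently built group at the same position, such as an amine or a carboxylic acid, would read the same. Going by these compounds, on the side chain, it also remains open how a smaller ether such as methoxy, or a longer carbon chain, would compare with methyl and benzyloxy.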